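The compounds below may be only part of what the source reports. "The series", "measured", "known", "first", "only" and "open" are said of these compounds alone.

Measured so far in a functional assay on KB cells (Homo sapiens) for cytotoxicity, read by MTT assay, with a stated time of 3 days; a lower number here means a stronger inhibitor, a higher number a weaker inhibitor:
Compound 1 `N#Cc1c(Cl)nc(SCc2nc3ccccc3[nH]2)nc1-c1ccccc1` gives 3.7 nM
Compound 2 `N#Cc1c(NN)nc(SCc2nc3ccccc3[nH]2)nc1-c1ccccc1` gives 2.55 nM
Compound 3 `CCNc1nc(SCc2nc3ccccc3[nH]2)nc(-c2ccccc2)c1C#N` gives 7.35 nM

All three share one core and differ only in a single group. Two steps fix where compound 3 stands. One is a 2.0-fold higher number from compound 1 to compound 3 (0.30 log units; within the scatter), which leaves it level with compound 1 on these numbers. The other is a 2.9-fold higher number from compound 2 to compound 3 (0.46 log units; beyond the scatter), which sets it modestly apart from compound 2.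

Compound 4 `N#Cc1c(NNC(N)=S)nc(SCc2nc3ccccc3[nH]2)nc1-c1ccccc1` has not yet been measured. It keeps the shared core and differs from compound 3 by one change: a group of 4 heavy atoms (1 carbon, 2 nitrogen, 1 sulfur; no ring) in place of a group of 2 heavy atoms (2 carbon; no ring), on a nitrogen on an aromatic ring.

Going by the values given here, three measured steps bear on this change, because each replaces the group at this place: a 1.5-fold lower number from compound 1 to compound 2 (0.16 log units; within the scatter), together with the two above. Among the compounds with values here, none of them is large, and only the step between compound 2 and compound 3 leaves the scatter. As far as these compounds go, a new group of this size is untested here, so the range must stay wide. A slight lean towards a lower number rests on compound 2, which has amino in place of ethyl on that nitrogen and gives 2.55 nM. No step beyond the scatter is expected. The expected step is a 1.6-fold lower number from compound 3 to compound 4 (0.21 log units; within the scatter). For compound 4 the estimated value is 4.5 nM, with an expected range from 1.5 nM to 13 nM.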

Compound 4, half-maximal inhibitory concentration: 3 nM
The estimate for compound 4 lay 1.5-fold (0.18 log units) above the measured number, within the range that was stated.
By their numbers in this assay, from the lowest: compounds 2, 4, 1 and 3 (each within the scatter of the next, the first and the last beyond it).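

In this assay the nitrogen on an aromatic ring carries a group of 4 heavy atoms with no loss against ethyl: the step is a 2.5-fold lower number from compound 3 to compound 4 (0.39 log units; beyond the scatter) and it shows that this place accepts a group larger than any seen there before, including one with 2 hydrogen-bond donors and a sulfur. Size alone does not separate the compounds at this place, since adding a group of 3 heavy atoms to the amine nitrogen gives a 1.2-fold higher number from compound 2 to compound 4 (0.07 log units; within the scatter) and replacing the chlorine atom on the aromatic carbon gives a 1.2-fold lower number from compound 1 to compound 4 (0.09 log units; within the scatter) so compound 4 stands level with both of them, and of the compounds compared here only compound 3, with its ethyl group, stands apart from compound 4. Nothing available here explains why these steps take the size they do.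

The compounds shown leave open whether the sulfur matters, which a carbonyl in its place would test on the same chain. They also leave open how far this place stretches, which a longer chain or a ring amine such as morpholine on the aromatic carbon would begin to show.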